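Methyl for hydrogen on the thiophene-linked phenyl ring

This account rests on a few compounds, and the source may have more. Where it says the series, first, only, none or still open, it means among the compounds named here.

Within the data shown here, two measured members so far. Compound 1 `Cc1ccc(C(=O)NNC(=S)Nc2csc(-c3ccc(C)cc3)c2)cc1` and compound 2 `O=C(NNC(=S)Nc1csc(-c2ccccc2)c1)c1ccc(O)cc1` share the same core and differ in the substituents on both outer rings. In a functional assay on Hs 683 cells (Homo sapiens) for inhibition, read by colorimetric assay and MTT assay, with a stated time of 72 h (on this read-out higher numbers stand for weaker inhibition and lower numbers for stronger inhibition), compound 1 gives 40000 nM. In this assay compound 2 gives 80000 nM. Compound 2 stands at one end of the pair of numbers, but the gap between compound 2 and compound 1 falls within the usual scatter of repeated measurements, so no ordering between the two can be read from these values.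

Compound 3 `Cc1ccc(-c2cc(NC(=S)NNC(=O)c3ccc(O)cc3)cs2)cc1` is not yet measured. It differs from compound 2 in one place: methyl in place of hydrogen on an aromatic carbon. Among the measured compounds shown here, no measured pair isolates this single change, so no step can be quoted for it. Given the closeness of compound 1 and compound 2, the change is expected to move this assay by no more than the scatter, in no confident direction. Compound 3 is therefore estimated at 55000 nM, with a range from 20000 nM to 150000 nM. The step from compound 2 to compound 3 that this estimate means is a 1.5-fold lower number from compound 2 to compound 3 (0.16 log units; within the scatter), expected to lie within the scatter.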

Compound 3, half-maximal inhibitory concentration: 49000 nM
Beside the measured number, compound 3's estimate is 1.1-fold (0.05 log units) above it; measured number inside the range.
By their numbers in this assay, from the lowest: compounds 1, 3 and 2 (each within the scatter of the next).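

In this assay, the change from phenyl to 4-methylphenyl, with the methyl para to a large group, now stands alone as a single change, and it reads a 1.6-fold lower number from compound 2 to compound 3 (0.21 log units; within the scatter); at this position, on these numbers, methyl and hydrogen cannot be told apart. The second single change, hydroxy in place of methyl on an aromatic carbon, reads a 1.2-fold higher number from compound 1 to compound 3 (0.09 log units; within the scatter), so the pair of compounds that differed on both outer rings now splits into two separate changes, each within the scatter, and neither change alone is seen to shift the read-out. Nothing measured here speaks to the reason for these readings.

Open is whether any group at this position can move the number beyond the scatter, since only hydrogen and methyl are shown there and an amine, a carboxylic acid or a longer chain such as ethyl could read differently. With all three compounds within the scatter of one another, the series also offers no reference for which of its parts the read-out depends on, and changes to the shared core remain untested in the compounds shown.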